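Swapping the basic ring on a thienopyrimidinone antagonist

The source may report more compounds than this note shows. Statements on the series, on what has been measured and on what is new or still open speak of the compounds shown alone.

Of the compounds shown here, three sharing one core have been measured in a functional assay on CHO cells for antagonist activity at melanin-concentrating hormone receptor 1 (Homo sapiens), read by reporter gene assay; a higher number here means a weaker inhibitor, a lower number a stronger inhibitor. Compound 1 `O=c1c2sc(-c3ccc(Cl)cc3)cc2ncn1-c1ccc2c(c1)CCC(CN1CCCCC1)C2` gives 3.1 nM. Compound 2 `O=c1c2sc(-c3ccc(Cl)cc3)cc2ncn1-c1ccc2sc(CN3CCCC3)cc2c1` gives 0.91 nM. Compound 3 `O=c1c2sc(-c3ccc(Cl)cc3)cc2ncn1-c1ccc2sc(CN3CCCCC3)cc2c1` gives 2 nM, the second highest of the three numbers; its gap to compound 1 lies within the scatter, while a 2.2-fold higher number from compound 2 to compound 3 (0.34 log units; beyond the scatter) lies beyond it, so the pyrrolidine of compound 2 and the piperidine of compound 3 are not interchangeable without a modest cost.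

Compound 4 `CN1CCN(Cc2cc3cc(-n4cnc5cc(-c6ccc(Cl)cc6)sc5c4=O)ccc3s2)CC1` has not yet been measured. It differs from compound 3 in one place: 4-methylpiperazin-1-yl in place of piperidin-1-yl on a saturated chain carbon bound to an aromatic carbon. Among the compounds with values here, the only measured step that touches the same spot is the one from compound 2 to compound 3, and it was modest. Within the data shown here, no measured pair covers a methylpiperazine, so the expectation rests on that single step alone. Compound 4 is expected to sit close to compound 3 or somewhat above it, with a 2.3-fold higher number from compound 3 to compound 4 (0.35 log units; beyond the scatter) as the estimated shift. Compound 4 is therefore estimated at 4.5 nM, within a range of 1.5 nM to 14 nM.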

Compound 4, half-maximal inhibitory concentration: 9.7 nM
Compound 4: the middle estimate sits 2.2-fold (0.33 log units) below what was measured; measured number inside the range.
By their numbers in this assay, from the lowest: compound 2; then compounds 3 and 1 (each within the scatter of the next); then compound 4.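

In this assay, this place on the saturated chain carbon proves sensitive to the ring it carries: replacing piperidin-1-yl with 4-methylpiperazin-1-yl gives a 4.9-fold higher number from compound 3 to compound 4 (0.69 log units; beyond the scatter). Across the three rings on the shared core, the numbers climb from pyrrolidin-1-yl through piperidin-1-yl to 4-methylpiperazin-1-yl, and the two ends are separated by an 11-fold higher number from compound 2 to compound 4 (1.03 log units; beyond the scatter), a large step where the earlier compounds had shown only a modest one. No supporting data bear on why the added ring nitrogen and its methyl go with a weaker inhibitor.

Still open, on these data alone, is which part of the change carries the loss, the ring nitrogen or the methyl on it; an unsubstituted piperazin-1-yl or a morpholin-4-yl ring would help separate the two. As far as these compounds go, whether the step holds on the core of compound 1 also remains unknown.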